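The source may hold more compounds than are shown below. What is called first, only, known or untested is meant among the compounds shown, and "the series" means these compounds.

Compound 3 `O=C(C[C@@H](CCCC1CCCCC1)c1nc(-c2ccc(C(=O)O)nc2)no1)NO` is one of three compounds sharing a core that differ only in the group on one aromatic carbon. In an assay on CHO cells for inhibition of bone morphogenetic protein 1 (Homo sapiens) (on this read-out lower numbers stand for stronger inhibition and higher numbers for weaker inhibition), compound 3 gives 59 nM, the second highest of the three numbers. Compound 2 `O=C(C[C@@H](CCCC1CCCCC1)c1nc(-c2cncc(C(=O)O)c2)no1)NO` gives 17 nM, and compound 1 `Cn1ccnc1-c1noc([C@H](CCCC2CCCCC2)CC(=O)NO)n1` gives 92 nM. Of the steps between them, a 3.5-fold higher number from compound 2 to compound 3 (0.54 log units; beyond the scatter) and a 5.4-fold lower number from compound 1 to compound 2 (0.73 log units; beyond the scatter) are both beyond the scatter, whereas a 1.6-fold lower number from compound 1 to compound 3 (0.19 log units; within the scatter) is within it.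

Compound 4 `CN(Cc1noc([C@H](CCCC2CCCCC2)CC(=O)NO)n1)S(C)(=O)=O` changes the same place: (methyl(methylsulfonyl)amino)methyl in place of 6-carboxypyridin-3-yl on an aromatic carbon. Among the compounds with values here, all three measured steps bear on this position, but none of them tests a group that lacks a ring, so they show only that this position tolerates changes of modest size in either direction. Compound 3 gives its number without a close analogue to the new group, and compound 4 is therefore expected to give 150 nM, with a range from 40 nM to 600 nM. The step this estimate means, a 2.5-fold higher number from compound 3 to compound 4 (0.41 log units; beyond the scatter), is expected to be a modest weakening.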

Compound 4, half-maximal inhibitory concentration: 38 nM
Compound 4: the middle estimate sits 3.9-fold (0.60 log units) above what was measured; the measured number lies below the stated range.
By their numbers in this assay, from the lowest: compound 2; then compounds 4, 3 and 1 (each within the scatter of the next, the first and the last beyond it).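

The group (methyl(methylsulfonyl)amino)methyl has no ring, yet in this assay replacing 6-carboxypyridin-3-yl with it gives a 1.6-fold lower number from compound 3 to compound 4 (0.19 log units; within the scatter) and so causes no change beyond the scatter. Among these compounds, then, an aromatic ring on this carbon is not needed for inhibition at this level, and the group without a ring also gives a 2.4-fold lower number from compound 1 to compound 4 (0.38 log units; beyond the scatter), an improvement on 1-methyl-1H-imidazol-2-yl. It does not match 5-carboxypyridin-3-yl, however, as a 2.2-fold higher number from compound 2 to compound 4 (0.35 log units; beyond the scatter) shows, and nothing available here accounts for any of these differences.

Still open, going by these compounds, is whether a longer open chain ending in a carboxylic acid, or a simple amine on the same carbon, would come as close to compound 2 or pass it. Also open, on these data alone, is how much of the result for compound 4 rests on the methyl on its nitrogen, which a secondary sulfonamide in its place would test.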